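Hydrazone aroyl variation: thiophene to bromophenyl at the carbonyl

The source may report more compounds than this note shows. Statements on the series, on what has been measured and on what is new or still open speak of the compounds shown alone.

This account covers three measured hydrazones and one yet to be tested. In an ADME assay on cells (Homo sapiens) for antiproliferative activity, read by MTT assay (a lower number here means a stronger inhibitor, a higher number a weaker inhibitor), compound 1 `C/C(=N\NC(=O)c1ccc(C(F)(F)F)cc1)c1cnccn1` gives 1160 nM and compound 2 `C/C(=N\NC(=O)c1ccncc1)c1cnccn1` gives 5790 nM. Compound 3 `O=C(NN=C(c1ccccn1)c1ccccn1)c1cccs1` gives 950 nM in this assay, the lowest of the three numbers; its gap to compound 1 lies within the scatter, while compound 2 sits beyond the scatter from it. Compound 4 `O=C(NN=C(c1ccccn1)c1ccccn1)c1ccc(Br)cc1` has not yet been measured. It differs from compound 3 in one place: 4-bromophenyl in place of thiophen-2-yl on a carbonyl carbon. The carbonyl carbon that carries the new group still has an amide-type nitrogen as its other neighbour, and the rest of the shared core is unchanged. Within the data shown here, no measured pair in the set isolates this particular exchange, so the size of the step can only be guessed. A modest change, if any, is expected, since compound 3 gives 950 nM and aroyl groups elsewhere in the set span a limited range. The step from compound 3 to compound 4 is expected to be a 1.2-fold lower number from compound 3 to compound 4 (0.07 log units; within the scatter). Compound 4 is estimated at 800 nM in this assay, with a range from 300 nM to 2500 nM.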

Compound 4, half-maximal inhibitory concentration: 300 nM
The estimate for compound 4 lay 2.7-fold (0.43 log units) above the measured number; the measured number falls inside the stated range.
By their numbers in this assay, from the lowest: compound 4; then compounds 3 and 1 (each within the scatter of the next); then compound 2.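

In this assay, 4-bromophenyl in place of thiophen-2-yl on a carbonyl carbon gives a 3.2-fold lower number from compound 3 to compound 4 (0.50 log units; beyond the scatter). Among these compounds, this is the only step in the set that isolates a single change, and it shows that the group on this carbonyl carbon can, with the rest of the shared core unchanged, move the number beyond the scatter. The earlier compounds, which differ in more than one place, could not show this, and no measured property bears on the result, so the step remains without an explanation.

The compounds shown leave open whether the bromine or the six-membered aromatic ring accounts for the step; a plain phenyl or a 4-chlorophenyl group on this carbonyl carbon would separate the two. They also leave open whether the same exchange would shift the number on the core of compound 1.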